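Swapping the Bicyclic Amide Head in a Sulfone Series

The source may hold more compounds than are shown below. What is called first, only, known or untested is meant among the compounds shown, and "the series" means these compounds.

Of the compounds shown here, three have been measured in an ADME assay on microsomes from liver (Homo sapiens) for metabolic stability, read by LC-MS, with a stated time of 30 min, tested at 1 uM; on this read-out higher numbers stand for a more stable compound and lower numbers for a less stable compound. Compound 1 `O=C(NCc1ccc(S(=O)(=O)c2ccccc2)cc1)c1nc2ccncc2s1` gives 68%, the highest of the three numbers. Compound 2 `O=C(NCc1ccc(S(=O)(=O)N2CCCCC2)cc1)c1cc2ccncc2[nH]1` gives 50%, and compound 3 `O=C(NCc1ccc(S(=O)(=O)N2CCCCC2)cc1)c1ccc2nc[nH]c2c1` gives 53%. Compound 1 stands beyond the scatter above both of the others; compound 3 lies nearest to it and compound 2 furthest.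

Among the measured compounds shown here, the only measured step between two compounds that differ in one place is a number 3 percentage points higher from compound 2 to compound 3 (within the scatter), which exchanges one bicyclic group on the carbonyl carbon for another and leaves the number within the scatter.

Compound 4 `O=C(NCc1ccc(S(=O)(=O)c2ccccc2)cc1)c1cc2cnccc2[nH]1` differs from compound 1 by a group of 9 heavy atoms (7 carbon, 2 nitrogen; one five-membered aromatic ring with 1 hetero atom, one six-membered aromatic ring with 1 hetero atom) in place of a group of 9 heavy atoms (6 carbon, 2 nitrogen, 1 sulfur; one five-membered aromatic ring with 2 hetero atoms, one six-membered aromatic ring with 1 hetero atom), on a carbonyl carbon. For the measured compounds named here, no measured step covers this particular exchange, so the step of a number 3 percentage points higher from compound 2 to compound 3 (within the scatter) is the only guide, and it shows that exchanging one bicycle on the carbonyl carbon for another need not move the number beyond the scatter. Compound 2, which also carries a five-membered aromatic ring with 1 hetero atom on its carbonyl carbon, sits below compound 1, but the two differ elsewhere as well, so that comparison settles nothing. On this basis compound 4 is expected to give 55%, within a range of 35% to 75%. That expectation means a step of a number 13 percentage points lower from compound 1 to compound 4 (beyond the scatter), a drop that may or may not exceed the scatter.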

Compound 4, percent of the compound remaining: 75%
Compound 4: the middle estimate sits 20 percentage points below what was measured, within the range that was stated.
By their numbers in this assay, from the lowest: compounds 2 and 3 (each within the scatter of the next); then compounds 1 and 4 (each within the scatter of the next).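

In this assay, the exchange on the carbonyl carbon gives a number 7 percentage points higher from compound 1 to compound 4 (within the scatter), so the group with one five-membered aromatic ring with 2 hetero atoms, sulfur among them, gave way to the group with one five-membered aromatic ring with 1 hetero atom without the number moving beyond the scatter, even though the count went from 0 hydrogen-bond donors to 1 hydrogen-bond donor and from 3 hydrogen-bond acceptors to 1 hydrogen-bond acceptor. Among the compounds shown here, until now the only reading at this position was a number 3 percentage points higher from compound 2 to compound 3 (within the scatter), on a different core, so there are now two exchanges of one bicycle for another, on two cores, and in neither does the number leave the scatter. Nothing measured here offers a reason for this tolerance.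

The compounds shown leave open whether this tolerance holds beyond bicycles of 9 heavy atoms, for instance with a single pyridine ring on the carbonyl carbon, or with an amine or a carboxylic acid attached to the bicycle. As far as these compounds go, no bicyclic group appears on both cores, so how much the rest of the molecule contributes to the number also remains open.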